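The source may report more compounds than this note shows. Statements on the series, on what has been measured and on what is new or still open speak of the compounds shown alone.

Compound 1 `FC1(F)CCC(NC/C=C/CN(C[C@H]2Cc3ccccc3CN2)[C@H]2CCCc3cccnc32)CC1` carries a 4,4-difluorocyclohexyl group on an amine nitrogen. In a functional assay on cells for agonist activity at C-X-C chemokine receptor type 4 (Homo sapiens), read by fluorescence and calcium flux, with a stated time of 90 s (a lower number here means that less compound is needed, a higher number that more compound is needed for the effect), compound 1 gives only a limit of the assay, > 30000 nM. Compound 2 `C(=C/CN(C[C@H]1Cc2ccccc2CN1)[C@H]1CCCc2cccnc21)\CNC1CCOCC1` differs from it by oxan-4-yl in place of 4,4-difluorocyclohexyl on an amine nitrogen. In this assay compound 2 likewise gives only a limit, > 30000 nM. The step that the two limits leave unreadable from compound 1 to compound 2 therefore cannot be sized, because both values sit at the limit of > 30000 nM in this assay, at which 3 of the 3 values shown sit. Compound 3 `CC(C)(CCN(C[C@H]1Cc2ccccc2CN1)[C@H]1CCCc2cccnc21)CNC1CCC(F)(F)CC1` shares the 4,4-difluorocyclohexyl group with compound 1, but the difference between the two cores is not broken down here. In this assay compound 3 gives only a limit, > 30000 nM. Compound 4 `CC(C)(CCN(C[C@H]1Cc2ccccc2CN1)[C@H]1CCCc2cccnc21)CNC1CCOCC1` differs from compound 3 by oxan-4-yl in place of 4,4-difluorocyclohexyl on an amine nitrogen, the same change on the same kind of amine nitrogen as that between compound 1 and compound 2. The expected step that the limit leaves unreadable from compound 3 to compound 4 is not readable either, since the earlier step is unreadable and every measured value sits at the limit of > 30000 nM in this assay, at which 3 of the 3 values shown sit. Compound 4 is expected to remain at the limit, estimated at 40000 nM, between 15000 nM and 100000 nM.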

Compound 4, half-maximal effective concentration: > 30000 nM
Compound 4: no number, only a limit; the forecaster's own chance of this, stated with the estimate: 85%; the middle value does not contradict the limit.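

In this assay compound 4 gives only a limit, > 30000 nM. The change from compound 3 to compound 4 therefore has no readable size, because the values of both compounds sit at the same limit: the limit of > 30000 nM in this assay, at which 4 of the 4 values shown sit. The compounds shown leave open how much of each is needed for the effect, and whether swapping 4,4-difluorocyclohexyl for oxan-4-yl changes that amount at all.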